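Cytotoxicity across a shared core with varied amine substituents

A few compounds are considered here, and "the series" means these few. Any claim that something is new, unique, unknown or untested is made for them only; others in the source may bear on it.

Compound 3 `CN(c1ccncc1)N(c1cc(C#CC(C)(C)C)sc1C(=O)O)C(=O)[C@H]1CC[C@H](C)CC1` gives the only numerical read-out in an ADME assay on Huh-7 cells (Homo sapiens) for cytotoxicity, read by fluorescence, with a stated time of 3 days (on this read-out higher numbers stand for lower toxicity in this test and lower numbers for higher toxicity in this test), namely 36000 nM. In this assay compound 1 `CC(C)N(c1cc(C#CC(C)(C)C)sc1C(=O)O)C(=O)[C@H]1CC[C@H](C)CC1` sits at a limit, > 44000 nM. In this assay compound 2 `CN(C)N(c1cc(C#CC(C)(C)C)sc1C(=O)O)C(=O)[C@H]1CC[C@H](C)CC1` likewise sits at a limit, > 44000 nM. The step that the two limits leave unreadable from compound 1 to compound 2 cannot be read between the two limits (the limit of > 44000 nM in this assay, at which 2 of the 3 values shown sit), while the steps of an at least 1.2-fold lower number from compound 1 to compound 3 (0.08 log units; that floor lies within the scatter) and an at least 1.2-fold lower number from compound 2 to compound 3 (0.08 log units; that floor lies within the scatter) remain within the scatter. Compound 4 `CN(CCO)N(c1cc(C#CC(C)(C)C)sc1C(=O)O)C(=O)[C@H]1CC[C@H](C)CC1` differs from compound 3 by 2-hydroxyethyl in place of pyridin-4-yl on an amine nitrogen. For the measured compounds named here, no measured step bears directly on a 2-hydroxyethyl group, and all three measured compounds stand at or near the limit, so compound 4 is expected to show no change beyond the scatter, a 1.2-fold higher number from compound 3 to compound 4 (0.09 log units; within the scatter). The estimate for compound 4 in this assay is 44000 nM, ranging from 28000 nM to 90000 nM.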

Compound 4, half-maximal cytotoxic concentration: > 44000 nM
Compound 4: only a limit was reported (the forecaster's own chance of this, stated with the estimate: 60%); the middle value lies on the limit itself.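

In this assay, for the compounds shown here, the 2-hydroxyethyl group, with no ring and 1 hydrogen-bond donor, is the first chain of its kind on this amine nitrogen, and putting it in place of pyridin-4-yl gives an at least 1.2-fold higher number from compound 3 to compound 4 (0.08 log units; that floor lies within the scatter). The value of compound 4 is a limit. The steps from compound 1 and from compound 2 to compound 4 cannot be read: the limit of > 44000 nM in this assay, at which 3 of the 4 values shown sit.

On these data alone, how far the true values of compound 1, compound 2 and compound 4 lie from that limit stays open. So does whether a 3-hydroxypropyl or a 2-aminoethyl group on this amine nitrogen would give a readable number.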